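Compound 4: a 2-methylcyclopropyl group on the amide nitrogen

The source may hold more compounds than are shown below. What is called first, only, known or untested is meant among the compounds shown, and "the series" means these compounds.

Three compounds share one core and differ only in the group on an amide-type nitrogen: compound 1 `CNC(=O)c1cc(C(=O)N[C@H]2[C@@H]3C[C@H](O)C[C@@H]32)cc2c1OC[C@@]2(C)c1ccccc1`, compound 2 `CNC(=O)c1cc(C(=O)N[C@H]2CC[C@H](O)CC2)cc2c1OC[C@@]2(C)c1ccccc1` and compound 3 `CNC(=O)c1cc(C(=O)N[C@H]2[C@@H]3COC[C@@H]32)cc2c1OC[C@@]2(C)c1ccccc1`. In a physicochemical assay for lipophilicity, at pH 7.4 (a higher number here means a more lipophilic compound, a lower number a more polar compound), compound 3 gives 3.7, level with compound 1 at 3.7, while compound 2 gives 3.3.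

The next compound, compound 4 `CNC(=O)c1cc(C(=O)N[C@H]2C[C@@H]2C)cc2c1OC[C@@]2(C)c1ccccc1`, has not yet been measured. It arises from compound 3 through one change: a group of 4 heavy atoms (4 carbon; one three-membered non-aromatic ring of carbon only) in place of a group of 6 heavy atoms (5 carbon, 1 oxygen; one three-membered non-aromatic ring of carbon only, one five-membered non-aromatic ring with 1 hetero atom), on an amide-type nitrogen. The group that leaves holds an oxygen, and the 2-methylcyclopropyl group that enters holds none.

Three measured steps give a sense of scale. The record shows a number 0.40 log units lower from compound 1 to compound 2 (beyond the scatter), then a number 0.40 log units higher from compound 2 to compound 3 (beyond the scatter), and finally no change at the digits printed from compound 1 to compound 3 (within the scatter). Within the data shown here, every group in these steps carries an oxygen, so no measured pair tests its loss directly. The steps therefore suggest a size, not a direction, and the upward direction taken here is a judgement resting on that oxygen leaving. A modest rise is expected, matching the size of the largest measured change, and the estimated step is a number 0.40 log units higher from compound 3 to compound 4 (beyond the scatter). For compound 4 the estimated value is 4.1, with an expected range of 3.7 to 4.5.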

Compound 4, distribution coefficient: 4.7
Estimate against measurement, compound 4: 0.60 log units below; the measured number lies above the stated range.
By their numbers in this assay, from the lowest: compound 2; then compounds 1 and 3 (each within the scatter of the next); then compound 4.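

Among these compounds, measured by this assay this place on the amide-type nitrogen proves able to shift the number further than the earlier compounds showed, for the 2-methylcyclopropyl group gives a clear rise over each of the three groups it can replace (a number 1.00 log units higher from compound 3 to compound 4 (beyond the scatter); a number 1.00 log units higher from compound 1 to compound 4 (beyond the scatter); a number 1.40 log units higher from compound 2 to compound 4 (beyond the scatter)). The earlier steps compared only groups that carry an oxygen, whereas compound 4 brings the first group here with none, and it stands above all three oxygen-bearing compounds, with no compound shown going against that order. Nothing in the data gives a measured explanation for the size of this rise.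

Each step to compound 4 removes the oxygen and also changes the size and ring makeup of the group, so the compounds shown cannot separate the contribution of the oxygen from that of the carbon framework. A 2-(hydroxymethyl)cyclopropyl group, which would restore an oxygen on the same three-membered ring, or a plain cyclohexyl group, which would remove the oxygen from the group of compound 2, remains an open comparison.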